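Aryl halogen pattern and microsomal half-life in the series

The source may hold more compounds than are shown below. What is called first, only, known or untested is meant among the compounds shown, and "the series" means these compounds.

Measured compounds:
compound 1 `C=CC(=O)NCc1coc(-c2c(N)ncnc2Nc2ccc(Oc3cccc(F)c3)c(Cl)c2)n1`: > 1.66 h
compound 2 `C=CC(=O)NCc1coc(-c2c(N)ncnc2Nc2ccc(F)c(Cl)c2)n1`: 0.15 h

For the measured compounds named here, in an in vitro ADME assay on microsomes from liver (Mus musculus) for metabolic stability, tested at 5 uM (a higher number here means that the compound lasts longer, a lower number that the compound disappears faster), compound 2 gives 0.15 h, the only plain number among the values shown. For compound 1 the value > 1.66 h is a limit of the assay, not a number; this is the limit of > 1.66 h in this assay, at which 1 of the 2 values shown sits. Going by the values given here, the single measured step, an at least 11-fold lower number from compound 1 to compound 2 (1.04 log units; beyond the scatter), exchanged a 3-fluorophenoxy group for fluoro. Compound 3 `C=CC(=O)NCc1coc(-c2c(N)ncnc2Nc2ccc(Cl)c(Cl)c2F)n1` differs from compound 2 by 3,4-dichloro-2-fluorophenyl in place of 3-chloro-4-fluorophenyl on a nitrogen on an aromatic ring. Among the compounds with values here, no measured step exchanges one halogenated phenyl for another, so nothing here shows a large effect of such a swap. Compound 3 is therefore expected near compound 2, with an estimated 0.22 h (range 0.08 h to 0.6 h). The expected step of a 1.5-fold higher number from compound 2 to compound 3 (0.17 log units; within the scatter) stays within the scatter.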

Compound 3, half-life: 1.23 h
The estimate for compound 3 lay 5.6-fold (0.75 log units) below the measured number; measured number outside the range, above it.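

In this assay, 3,4-dichloro-2-fluorophenyl in place of 3-chloro-4-fluorophenyl on a nitrogen on an aromatic ring gives an 8.2-fold higher number from compound 2 to compound 3 (0.91 log units; beyond the scatter). A change confined to the halogens on this phenyl is thus enough to move the half-life beyond the scatter, with no 3-fluorophenoxy group present, which the earlier step could not show. Nothing measured here bears on why the number rises.

From the compounds shown here alone, the two phenyl groups differ in more than one halogen at once, so the share of each halogen stays open. Going by these compounds, whether a nitrile or a methoxy group on this phenyl would hold the half-life also stays open.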